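The source may hold more compounds than are shown below. What is called first, only, known or untested is meant among the compounds shown, and "the series" means these compounds.

Compound 3 `Cn1cncc1CN1CC(N(CC2CCN(C(=O)c3cccs3)CC2)S(=O)(=O)c2ccccn2)Cc2cc(C#N)ccc21`: 0.5 10^-6 cm/s
Compound 1 `Cn1cncc1CN1CC(N(CC2CCN(C(=O)c3ccc(Cl)cc3)CC2)S(=O)(=O)c2ccccn2)Cc2cc(C#N)ccc21`: 0.5 10^-6 cm/s
Compound 2 `Cn1cncc1CN1CC(N(CC2CCN(C(=O)OC(C)(C)C)CC2)S(=O)(=O)c2ccccn2)Cc2cc(C#N)ccc21`: 15.5 10^-6 cm/s

In an ADME assay on Caco-2 cells (Homo sapiens) for permeability, in the apical to basolateral direction (on this read-out higher numbers stand for higher permeability and lower numbers for lower permeability), compound 3 is level with compound 1, the two together the lowest of the three numbers; the step of no change at the digits printed from compound 1 to compound 3 (within the scatter) lies within the scatter, while a 31-fold lower number from compound 2 to compound 3 (1.49 log units; beyond the scatter) is large. Compound 4 `Cn1cncc1CN1CC(N(CC2CCN(S(=O)(=O)c3ccccc3)CC2)S(=O)(=O)c2ccccn2)Cc2cc(C#N)ccc21` differs from compound 3 in one place: phenylsulfonyl in place of (thiophen-2-yl)carbonyl on an amine nitrogen in a ring. The step of no change at the digits printed from compound 1 to compound 3 (within the scatter), an exchange of groups on a carbonyl carbon at the same ring nitrogen, bears most directly on this change and was flat. Going by the values given here, the step of a 31-fold higher number from compound 1 to compound 2 (1.49 log units; beyond the scatter) shows the position can move the read-out strongly, but only toward tert-butoxy; no measured step involves phenylsulfonyl. Compound 4 is therefore expected to stay near compound 3, with a 1.4-fold higher number from compound 3 to compound 4 (0.15 log units; within the scatter) inside the scatter. The estimate for compound 4 is 0.7 10^-6 cm/s (range 0.3 10^-6 cm/s to 1.8 10^-6 cm/s).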

Compound 4, apparent permeability: 0.1 10^-6 cm/s
Compound 4: the middle estimate sits 7.0-fold (0.85 log units) above what was measured, outside the stated range (below it).
By their numbers in this assay, from the lowest: compound 4; then compounds 1 and 3 (each within the scatter of the next); then compound 2.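

In this assay, the amine nitrogen in a ring separates more than tert-butoxycarbonyl from the aromatic carbonyl groups: phenylsulfonyl gives a 5.0-fold lower number from compound 3 to compound 4 (0.70 log units; beyond the scatter) and a 5.0-fold lower number from compound 1 to compound 4 (0.70 log units; beyond the scatter), whereas exchanging those two carbonyl groups left the number flat. Against tert-butoxycarbonyl, phenylsulfonyl gives a 160-fold lower number from compound 2 to compound 4 (2.19 log units; beyond the scatter), the widest gap in the set. Nothing measured here accounts for these steps.

Left open is whether the lower number goes with the sulfonyl link or with its phenyl ring, and whether methylsulfonyl or methoxycarbonyl on this nitrogen would sit nearer compound 2 or compound 4.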